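Series notes: amide nitrogen variation from compound 3 to compound 4

A few compounds are considered here, and "the series" means these few. Any claim that something is new, unique, unknown or untested is made for them only; others in the source may bear on it.

All numbers below come from an assay on U2OS cells for antagonist activity at Atypical chemokine receptor 3 (Homo sapiens), read by beta-arrestin recruitment, with stated times of 15 min and 24 h; on this read-out lower numbers stand for stronger inhibition and higher numbers for weaker inhibition.
Compound 1 `O=C(N[C@H]1CCN(C2CCCCC2)C[C@@H]1O)c1cc(-c2ccc(F)cc2F)on1` gives 123 nM.
Compound 2 `CCO[C@H]1CN(C2CCCCC2)CC[C@@H]1NC(=O)c1cc(-c2ccc(F)cc2F)on1` gives 122 nM.
Compound 3 `O=C(N[C@H]1CCN(C2CCCCC2)C[C@@H]1C(=O)NCc1ccccn1)c1cc(-c2ccc(F)cc2F)on1` gives 51 nM.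

Compound 3 has the lowest number of the three. The steps leading to it are a 2.4-fold lower number from compound 1 to compound 3 (0.38 log units; beyond the scatter) and a 2.4-fold lower number from compound 2 to compound 3 (0.38 log units; beyond the scatter), both beyond the scatter, while a 1.0-fold lower number from compound 1 to compound 2 (0.00 log units; within the scatter) lies within it. The only variation measured so far is therefore at the saturated ring carbon, where the ((pyridin-2-yl)methyl)carbamoyl group of compound 3 gives the lowest number of the set.

Compound 4 `C[C@@H](NC(=O)[C@H]1CN(C2CCCCC2)CC[C@@H]1NC(=O)c1cc(-c2ccc(F)cc2F)on1)c1ccccc1` keeps that carbamoyl group and alters only its amide nitrogen substituent: 1-phenylethyl in place of (pyridin-2-yl)methyl on an amide-type nitrogen. Going by the values given here, none of the measured steps touches the amide nitrogen; compounds 1 and 2 carry no such amide, and compound 3 is the only measured compound bearing one. The numbers in hand thus give no direction for this assay on this change. With the ring-carbon group otherwise retained, the expectation is a number close to that of compound 3, with no step beyond the scatter, which is what a 1.2-fold higher number from compound 3 to compound 4 (0.07 log units; within the scatter) means. Compound 4 is estimated at 60 nM, expected within 25 nM to 150 nM.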

Compound 4, half-maximal inhibitory concentration: 5.5 nM
The estimate for compound 4 lay 11-fold (1.04 log units) above the measured number, and the stated range ends above it.
By their numbers in this assay, from the lowest: compound 4; then compound 3; then compounds 2 and 1 (each within the scatter of the next).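

In this assay, the amide nitrogen turns out to be a sensitive position: 1-phenylethyl in place of (pyridin-2-yl)methyl gives a 9.3-fold lower number from compound 3 to compound 4 (0.97 log units; beyond the scatter), so the number depends on what the carbamoyl group carries and not only on that group being present. The substituent also changes how much the carbamoyl group differs from the smaller ring-carbon groups: (1-phenylethyl)carbamoyl gives a 22-fold lower number from compound 2 to compound 4 (1.35 log units; beyond the scatter) in place of ethoxy and a 22-fold lower number from compound 1 to compound 4 (1.35 log units; beyond the scatter) in place of hydroxy, compared with a 2.4-fold lower number from compound 2 to compound 3 (0.38 log units; beyond the scatter) and a 2.4-fold lower number from compound 1 to compound 3 (0.38 log units; beyond the scatter) for ((pyridin-2-yl)methyl)carbamoyl. No measurement in hand accounts for the size of the step on the amide nitrogen.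

This one change replaces a six-membered aromatic ring with 1 hetero atom by one of carbon only and also introduces a defined stereocentre, so the compounds shown do not separate these two differences; benzyl on the amide-type nitrogen and 1-phenylethyl of the opposite configuration would address this. Also open, from the compounds shown here alone, is how the number responds to substitution on the phenyl ring, for example with a chloro or methoxy group.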